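A Ring Swap on a Potent Antagonist Core

The compounds below may be only part of what the source reports. "The series", "measured", "known", "first", "only" and "open" are said of these compounds alone.

Measured in an assay on CHO cells for antagonist activity at transient receptor potential cation channel subfamily V member 1 (Homo sapiens), read by FLIPR and calcium flux; on this read-out higher numbers stand for weaker inhibition and lower numbers for stronger inhibition:
compound 1 `CCC1CCC(c2nc(C(F)(F)F)ccc2CNC(=O)C(C)c2ccc(NS(C)(=O)=O)c(F)c2)CC1` gives 0.3 nM
compound 2 `C[C@H](C(=O)NCc1ccc(C(F)(F)F)nc1C1CC2CCC1C2)c1ccc(NS(C)(=O)=O)c(F)c1` gives 0.8 nM

Of the two measured compounds, compound 1 stands at the lowest number in this assay, that is, the stronger inhibition; the number for compound 2 is higher, by a gap beyond the usual scatter of repeated measurements. Both share the same core and differ only in the non-aromatic ring carried on that core.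

Compound 3 `CC(C(=O)NCc1ccc(C(F)(F)F)nc1C1=CCC(C)(C)CC1)c1ccc(NS(C)(=O)=O)c(F)c1` has not yet been measured. It comes from compound 1 by a single change: 4,4-dimethylcyclohex-1-en-1-yl in place of 4-ethylcyclohexyl on an aromatic carbon. The leaving group and the entering group are counted alike in heavy atoms, each is a six-membered non-aromatic ring of carbon only, and neither carries a hydrogen-bond donor or acceptor; the entering group brings one double bond outside aromatic rings.

Among the compounds with values here, no measured pair shows a change of this kind, so there is no step to lean on. With the two groups matching so closely in what is counted, a step in this assay of about the usual scatter, toward a somewhat higher number, is expected. For compound 3 the estimate is 0.6 nM, with a range from 0.2 nM to 2 nM. This is expected to be a step of a 2.0-fold higher number from compound 1 to compound 3 (0.30 log units; within the scatter).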

Compound 3, inhibition constant: 0.2 nM
Compound 3: the middle estimate sits 3.0-fold (0.48 log units) above what was measured; the range from low to high includes it.
By their numbers in this assay, from the lowest: compounds 3 and 1 (each within the scatter of the next); then compound 2.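

In this assay, placing 4,4-dimethylcyclohex-1-en-1-yl instead of 4-ethylcyclohexyl on the aromatic carbon next to the ring nitrogen gives a 1.5-fold lower number from compound 1 to compound 3 (0.18 log units; within the scatter), so this read-out cannot tell compound 1 and compound 3 apart. The position therefore accepts a second carbon ring of the same size and the same heavy-atom count without a measurable loss of inhibition, even though the new ring has one double bond outside aromatic rings and carries two methyl groups on one ring carbon in place of a single ethyl group. Nothing measured here explains why these two rings give readings so close together.

Because the double bond and the switch from ethyl to two methyl groups arrive together, the compounds shown cannot separate the contribution of each; the saturated 4,4-dimethylcyclohexyl group would be the direct test, as it keeps the two methyl groups and lacks the double bond. All the rings shown at this position are also pure carbon, so the outcome with an amine or a hydroxyl group on the ring remains open.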